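Chloro to hydroxy on the pendant phenyl, compound 3 to 4

The source may hold more compounds than are shown below. What is called first, only, known or untested is meant among the compounds shown, and "the series" means these compounds.

Measured so far in a functional assay on the whole organism (strain albino) for inhibition, with Rattus norvegicus as the target, read by paw edema, with stated times of 1 h and 0.5 h, at a dose of 100 mg/kg by the oral route; a lower number here means less inhibition, a higher number more inhibition at the dose given (going by the name of the read-out):
compound 1 `N#Cc1c(Cl)nc(SCC(=O)Nn2c(COc3ccc(Cl)cc3Cl)nc3ccccc3c2=O)nc1-c1ccc(Cl)cc1` gives 61.5%
compound 2 `N#Cc1c(Cl)nc(SCC(=O)Nn2c(COc3ccc(Cl)cc3Cl)nc3ccccc3c2=O)nc1-c1ccc(O)cc1` gives 67.3%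
compound 3 `N#Cc1c(Nc2ccc(Cl)cc2)nc(SCC(=O)Nn2c(COc3ccc(Cl)cc3Cl)nc3ccccc3c2=O)nc1-c1ccc(Cl)cc1` gives 46.2%

Compound 3 stands lowest of the three numbers. Compound 1 is nearest to it, the step being a number 15.3 percentage points lower from compound 1 to compound 3 (beyond the scatter); compound 2 stands furthest from it, and the two values of compound 2 and compound 3 lie beyond the scatter of each other.

Compound 4 `N#Cc1c(Nc2ccc(Cl)cc2)nc(SCC(=O)Nn2c(COc3ccc(Cl)cc3Cl)nc3ccccc3c2=O)nc1-c1ccc(O)cc1` is the unmeasured member. It differs from compound 3 by hydroxy in place of chloro on an aromatic carbon.

For the measured compounds named here, one measured step bears on this change. The same exchange, hydroxy in place of chloro on an aromatic carbon, is seen from compound 1 to compound 2: a number 5.8 percentage points higher from compound 1 to compound 2 (within the scatter). That step stays within the scatter, so no step beyond the scatter is expected here either. For compound 4 the expected step is a number 4.8 percentage points higher from compound 3 to compound 4 (within the scatter). Compound 4 is therefore estimated at 51% in this assay, with a range from 38% to 64%.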

Compound 4, a percentage reported as inhibition, in the whole organism at one dose (the size of the read-out at that dose, not a potency): 65.4%
Beside the measured number, compound 4's estimate is 14.4 percentage points below it; measured number outside the range, above it.
By their numbers in this assay, from the lowest: compound 3; then compounds 1, 4 and 2 (each within the scatter of the next).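

In this assay, hydroxy in place of chloro on the six-membered aromatic ring now gives a step beyond the scatter, a number 19.2 percentage points higher from compound 3 to compound 4 (beyond the scatter), yet this step cannot be separated from the earlier one: the same change on two cores in this assay, a number 5.8 percentage points higher (within the scatter) from compound 1 to compound 2 and a number 19.2 percentage points higher (beyond the scatter) from compound 3 to compound 4, 13.4 percentage points apart, within the scatter of two such steps. With hydroxy in place, (4-chlorophenyl)amino in place of chloro gives a number 1.9 percentage points lower from compound 2 to compound 4 (within the scatter), against a number 15.3 percentage points lower from compound 1 to compound 3 (beyond the scatter), and these two steps also cannot be separated: the same change on two cores in this assay, a number 15.3 percentage points lower (beyond the scatter) from compound 1 to compound 3 and a number 1.9 percentage points lower (within the scatter) from compound 2 to compound 4, 13.4 percentage points apart, within the scatter of two such steps. The lower number of compound 3 is thus not a fixed result of the (4-chlorophenyl)amino group, although a real dependence of one change on the other is not established.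

Open, going by these compounds, is whether methoxy or an amino group on this ring would give numbers like those of hydroxy. Also open, on these data alone, is how a morpholine or a short alkylamine would read in place of the (4-chlorophenyl)amino group.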